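The source may hold more compounds than are shown below. What is called first, only, known or untested is meant among the compounds shown, and "the series" means these compounds.

Measured compounds:
- compound 1 `Cn1nc(-c2nnc(SCc3ccc(C(F)(F)F)cc3)o2)cc1-c1ccc(C(F)(F)F)cc1`: 29200 nM
- compound 2 `Cn1nc(-c2ccc(C(F)(F)F)cc2)cc1-c1nnc(S)o1`: "not determined" (no result reported)

Compound 1 was tested in a functional assay on A549 cells (Homo sapiens) for cytotoxicity, read by MTT assay, with a stated time of 24 h (a higher number here means a weaker inhibitor, a lower number a stronger inhibitor), and gives 29200 nM, a weak result on this scale. Compound 2 shares the same core and the same trifluoromethyl-bearing aromatic ring, but carries a bare sulfanyl group where compound 1 carries a longer substituent; for compound 2 this assay reports "not determined" (no result reported), so there is no single number to place it against compound 1.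

Compound 3 `Cn1nc(-c2ccc(C(F)(F)F)cc2)cc1-c1nnc(SCCc2ccc(F)cc2)o1` is compound 2 with one change: 2-(4-fluorophenyl)ethyl in place of hydrogen on a sulfur. Within the data shown here, no measured pair shows what this particular extension does, so the expected size of the step in this assay cannot be read from a neighbouring example. Among the measured compounds shown here, the only anchor is compound 1, which also carries an aromatic group joined to that sulfur through a short linker.

Because compound 1 gives 29200 nM in this assay, compound 3 is expected to land in the same weak region, estimated at 30000 nM with a range from 8000 nM to 110000 nM.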

Compound 3, half-maximal inhibitory concentration: 84200 nM
Compound 3: middle estimate off by 2.8-fold (0.45 log units), on the low side, within the range that was stated.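

Among these compounds, compound 2 has no single number in this assay and so no step from it to compound 3 can be read from these results. The compounds shown leave open what placing 2-(4-fluorophenyl)ethyl on the sulfur does to the value in this assay on its own. No other data here bear on the result for compound 3.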